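Furanocembranoid series: opening the butenolide of compound 1

This account rests on a few compounds, and the source may have more. Where it says the series, first, only, none or still open, it means among the compounds named here.

Measured so far:
compound 1 `CC1=C(O)[C@@H](C/C(C)=C\CC[C@H](C)/C=C/C=C(\C)CCCc2ccoc2)OC1=O` — 9.8 ug/mL
compound 2 `CCC(C)CN1CC=C(CCC/C(C)=C/C=C/[C@@H](C)CC/C=C(/C)C[C@H]2OC(=O)C(C)=C2O)C1=O` — 25.2 ug/mL

In a functional assay on XF498 cells (Homo sapiens) for cytotoxicity (on this read-out lower numbers stand for an effect already at smaller amounts and higher numbers for an effect only at larger amounts of compound), compound 1 gives 9.8 ug/mL, the lowest of the two numbers at hand; its nearest neighbour is compound 2 at 25.2 ug/mL, reached by a 2.6-fold higher number from compound 1 to compound 2 (0.41 log units; beyond the scatter). Compound 3 `COC(=O)C(O)C/C(C)=C\CC[C@H](C)/C=C/C=C(\C)CCCc1ccoc1` has not yet been measured. It differs from compound 1 by a group of 6 heavy atoms (3 carbon, 3 oxygen; no ring) in place of a group of 8 heavy atoms (5 carbon, 3 oxygen; one five-membered non-aromatic ring with 1 hetero atom), on a saturated chain carbon bound to a double-bonded chain carbon. Among the compounds with values here, the one measured step, a 2.6-fold higher number from compound 1 to compound 2 (0.41 log units; beyond the scatter), concerns a change at the other end of the chain and does not bear on this exchange, so no direct guide exists. Within the data shown here, with the ring that leaves being the only part of compound 1 not shared with compound 3, a shift toward a higher number in this assay is expected, of a size estimated as a 2.6-fold higher number from compound 1 to compound 3 (0.41 log units; beyond the scatter). Compound 3 is therefore estimated at 25 ug/mL, within 8 ug/mL to 80 ug/mL.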

Compound 3, concentration for half-maximal effect: 24.3 ug/mL
Compound 3: the middle estimate sits 1.0-fold (0.01 log units) above what was measured, and the stated range covers the measured number.
By their numbers in this assay, from the lowest: compound 1; then compounds 3 and 2 (each within the scatter of the next).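

In this assay, the ring at the saturated chain carbon bound to a double-bonded chain carbon can be replaced by hydroxy(methoxycarbonyl)methyl at a modest cost: a 2.5-fold higher number from compound 1 to compound 3 (0.39 log units; beyond the scatter). This end of the molecule, which the earlier pair left unchanged, therefore also bears on the read-out, yet the intact ring is not needed for a measurable effect, with compound 3 giving 24.3 ug/mL. No supporting measurement accounts for the size of this step.

Going by these compounds, it remains open whether the step reflects the loss of the ring or the methyl ester itself, a question that the free carboxylic acid or a primary amide at the same place could address. On these data alone, it also remains open whether the same exchange gives a similar step on the core of compound 2.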